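Series notes: aryl in place of bromo on the shared core

A few compounds are considered here, and "the series" means these few. Any claim that something is new, unique, unknown or untested is made for them only; others in the source may bear on it.

Measured compounds:
- compound 1, `Brc1cn2ccnc2c(-c2ccc3ncn(C4CCCCC4)c3c2)n1`, 13.1%
- compound 2, `CC(=O)c1ccc(-c2cn3ccnc3c(-c3ccc4ncn(C5CCCCC5)c4c3)n2)cc1`, 18.8%

In a functional assay on HCT-15 cells (Homo sapiens) for inhibition, read by sulforhodamine B assay, with a stated time of 48 h, tested at 10 uM (a lower number here means less inhibition, a higher number more inhibition at the concentration tested (going by the name of the read-out)), compound 1 gives 13.1%, the lower of the two numbers recorded; compound 2 gives 18.8%, and the two values lie within the scatter of each other. Within the data shown here, the one measured step, a number 5.7 percentage points higher from compound 1 to compound 2 (within the scatter), puts an aryl group onto the same aromatic carbon that carries the bromo in compound 1 and changes nothing beyond the scatter.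

Compound 3, `Fc1ccccc1-c1cn2ccnc2c(-c2ccc3ncn(C4CCCCC4)c3c2)n1`, is not yet measured in this assay. It differs from compound 1 by 2-fluorophenyl in place of bromo on an aromatic carbon. The step from compound 1 to compound 2 is the only one that bears on it: an aryl group entering in place of the bromo at this carbon, and it stayed within the scatter. An aryl group enters here too, so the expected step of a number 3.9 percentage points higher from compound 1 to compound 3 (within the scatter) is small, with no direction beyond the scatter. Compound 3 is therefore estimated at 17%, with a range of 5% to 30%.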

Compound 3, a percentage reported as inhibition, at one concentration (the size of the read-out at that concentration, not a potency): 6.18%
Compound 3: the middle estimate sits 10.8 percentage points above what was measured, within the range that was stated.
By their numbers in this assay, from the lowest: compounds 3, 1 and 2 (each within the scatter of the next, the first and the last beyond it).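

In this assay the choice of aryl group at this carbon counts, with a number 12.6 percentage points lower from compound 2 to compound 3 (beyond the scatter) for 2-fluorophenyl in place of 4-acetylphenyl. Bromo and 2-fluorophenyl still cannot be told apart, with a number 6.9 percentage points lower from compound 1 to compound 3 (within the scatter) on that change, so the only separation at this position so far lies between the two aryl groups, and neither aryl group separates from bromo. No evidence on hand accounts for the gap between the two aryl groups.

Going by these compounds, whether that gap follows the acetyl group or the fluorine remains open, and an unsubstituted phenyl at this carbon would bear on the question. Also open, on these data alone, is how an amine or a carboxylic acid in place of the bromo would read, and whether any group here gives a much larger inhibition.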